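Iodo to phenyl on a nucleoside core in K562 cells

The compounds below may be only part of what the source reports. "The series", "measured", "known", "first", "only" and "open" are said of these compounds alone.

Measured so far:
compound 1 `Nc1nc(N)c2c(-c3ccsc3)cn([C@@H]3O[C@H](CO)[C@@H](O)[C@H]3O)c2n1`: > 20000 nM
compound 2 `COc1nc(N)nc2c1c(-c1cc3ccccc3o1)cn2[C@@H]1O[C@H](CO)[C@@H](O)[C@H]1O`: 15500 nM
compound 3 `COc1ncnc2c1c(I)cn2[C@@H]1O[C@H](CO)[C@@H](O)[C@H]1O`: 14800 nM

All values come from a functional assay on K562 cells (Homo sapiens), read by MTT assay, with a stated time of 72 h; on this read-out higher numbers stand for weaker inhibition and lower numbers for stronger inhibition. For compound 1 the result is a limit of the assay and not a number, (the limit of > 20000 nM in this assay, at which 1 of the 3 values shown sits). Going by the values given here, compound 2 and compound 3 give numbers that sit within the scatter of each other, so neither can be set above the other; with the third value being a limit, compound 3 stands among the two numbers of the set with no step to any other compound that is beyond the scatter.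

The next compound is compound 4 `COc1ncnc2c1c(-c1ccccc1)cn2[C@@H]1O[C@H](CO)[C@@H](O)[C@H]1O`. It differs from compound 3 in one place: phenyl in place of iodo on an aromatic carbon. Among the compounds with values here, no step between measured compounds shows what such a change does in this assay, so the expectation rests only on the three values above. Compound 2 gives 15500 nM with a larger aromatic group on a related core, and that number lies close to compound 3. The step from compound 3 to compound 4 is therefore expected to be small, a 1.3-fold lower number from compound 3 to compound 4 (0.13 log units; within the scatter), and not clearly beyond the scatter in either direction. Compound 4 is estimated at 11000 nM, with a range from 3500 nM to 30000 nM.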

Compound 4, half-maximal inhibitory concentration: > 20000 nM
Compound 4 ended at the assay's limit; the forecaster's own chance of this, stated with the estimate: 25%; middle value at least 1.8-fold (0.25 log units) from the limit.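

In this assay, going by these compounds alone, the change from iodo to phenyl on this aromatic carbon gives the first readable step at this position, an at least 1.3-fold higher number from compound 3 to compound 4 (0.13 log units; that floor lies within the scatter), so the floor of the step does not by itself separate the two compounds. Compound 4 gives > 20000 nM, which is a limit of the assay and not a number, so the full size of the step cannot be read. Phenyl brings no lower number than iodo at this carbon, and the set now gathers at the limit: the limit of > 20000 nM in this assay, at which 2 of the 4 values shown sit.

Still open, on these data alone, is whether an amine, a carboxylic acid or a short alkyl chain on this carbon would give a number beyond the scatter from compound 3. Also open, as far as these compounds go, is whether the same change from iodo to phenyl would read alike on the core of compound 2.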